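Reversed-amide variant of compound 3: expected inhibition

The compounds below may be only part of what the source reports. "The series", "measured", "known", "first", "only" and "open" are said of these compounds alone.

Measured compounds:
compound 1, `O=C(O)c1ccc2noc(-c3ccc(N4CCCCC4)cc3)c2c1`, 240 nM
compound 2, `O=C(O)c1ccc2noc(-c3ccc(Oc4ccccn4)cc3)c2c1`, 1190 nM
compound 3, `CC(C)NC(=O)c1ccc(-c2onc3ccc(C(=O)O)cc23)cc1`, 350 nM

In an assay for inhibition of inositol hexakisphosphate kinase 2 (Homo sapiens), read by colorimetric assay, coupled enzyme assay and malachite green, with a stated time of 120 min, in the presence of a further agent that is not named here (on this read-out higher numbers stand for weaker inhibition and lower numbers for stronger inhibition), compound 3 stands second highest of the three numbers. Its nearest neighbour is compound 1, with a 1.5-fold higher number from compound 1 to compound 3 (0.16 log units; within the scatter); its furthest is compound 2, with a 3.4-fold lower number from compound 2 to compound 3 (0.53 log units; beyond the scatter). Compound 4 is `O=C(O)c1ccc2noc(-c3ccc(NC(=O)C4CCCC4)cc3)c2c1`; it differs from compound 3 by (cyclopentylcarbonyl)amino in place of isopropylcarbamoyl on an aromatic carbon.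

For the measured compounds named here, no measured step swaps one amide for another. The closest comparison is the step from compound 1 to compound 3, where the piperidin-1-yl ring gave way to the isopropylcarbamoyl chain and the number barely moved, with a 1.5-fold higher number from compound 1 to compound 3 (0.16 log units; within the scatter). The step from compound 2 to compound 3, a 3.4-fold lower number from compound 2 to compound 3 (0.53 log units; beyond the scatter), involves the (pyridin-2-yl)oxy group and bears less directly. Since a ring-to-chain exchange at this position stayed within the scatter, the return to a ring in compound 4 is expected to do so as well, giving a 1.1-fold lower number from compound 3 to compound 4 (0.04 log units; within the scatter) in this assay. Compound 4 is therefore estimated at 320 nM, with a range from 120 nM to 900 nM.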

Compound 4, half-maximal inhibitory concentration: 190 nM
For compound 4 the middle estimate is 1.7-fold (0.23 log units) above the measured one; measured number inside the range.
By their numbers in this assay, from the lowest: compounds 4, 1 and 3 (each within the scatter of the next); then compound 2.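

In this assay, the place on an aromatic carbon para to a large group takes an amide joined through its nitrogen as readily as one joined through its carbonyl: a 1.8-fold lower number from compound 3 to compound 4 (0.27 log units; within the scatter) lies within the scatter, as does a 1.3-fold lower number from compound 1 to compound 4 (0.10 log units; within the scatter). The (pyridin-2-yl)oxy group of compound 2 remains the one substituent set apart, and the new amide separates from it as well, with a 6.3-fold lower number from compound 2 to compound 4 (0.80 log units; beyond the scatter). Nothing on hand explains these differences.

The step from compound 3 to compound 4 alters the amide direction and the carbon group together, so the two contributions stay unseparated. A cyclopentylcarbamoyl group would divide them, while a plain amine or a longer chain in this place remains an open case.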